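The compounds below may be only part of what the source reports. "The series", "measured", "known", "first", "only" and "open" are said of these compounds alone.

Working notes on the series. In a physicochemical assay for solubility, in phosphate buffer, at pH 7.4 (a higher number here means a more soluble compound, a lower number a less soluble compound), compound 1 (`CNC(=O)CN1CCC(c2cc3c(-c4ccc(=O)n(C(C)C)c4)ccnc3[nH]2)CC1`) gives 34000 nM and compound 2 (`COc1cc(F)ccc1-c1ccnc2[nH]c(C3CCN(CC(=O)N(C)C)CC3)cc12`) gives 38000 nM while compound 3 (`CC(C)n1cc(-c2ccnc3[nH]c(C4CCN(CC(=O)N(C)C)CC4)cc23)ccc1=O`) gives 110000 nM as the highest of the three numbers, with both others lower beyond the scatter.

Compound 4 (`CN(C)C(=O)CN1CCC(c2cc3c(-c4ccc(=O)n(C5CCC5)c4)ccnc3[nH]2)CC1`) has not yet been measured in this assay. It carries cyclobutyl in place of isopropyl on an aromatic nitrogen.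

Two measured steps lead to compound 3, but neither changes the group on that nitrogen. Methyl in place of hydrogen on an amide-type nitrogen gives a modest rise (a 3.2-fold higher number from compound 1 to compound 3 (0.51 log units; beyond the scatter)). The exchange of the group on an aromatic carbon gives a rise of similar size (a 2.9-fold higher number from compound 2 to compound 3 (0.46 log units; beyond the scatter)). These steps offer only a scale for single changes in this series and no direction for the new one. For the measured compounds named here, no measured step covers the isopropyl group, so the expectation is weak: no step beyond the scatter, with a slight lean downward that rests only on compound 3 standing highest at 110000 nM among the three. The expected step is a 1.4-fold lower number from compound 3 to compound 4 (0.14 log units; within the scatter) as an estimate. For compound 4 the estimated value is 80000 nM (expected range 40000 nM to 150000 nM).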

Compound 4, solubility: > 1000000 nM
Compound 4: no number, only a limit (the forecaster's own chance of this, stated with the estimate: 5%); at least 12-fold (1.09 log units) between middle value and limit.
By their numbers in this assay, from the lowest: compounds 1 and 2 (each within the scatter of the next); then compound 3. At a limit, above all of these: compound 4.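

In this assay, for the compounds shown here, the group on the aromatic nitrogen proves to be a sensitive place, one that no earlier step had touched: cyclobutyl in place of isopropyl gives an at least 9.0-fold higher number from compound 3 to compound 4 (0.95 log units; beyond the scatter), and this step already lies beyond the scatter. Compound 4 gives > 1000000 nM, which is a limit of the assay and not a number, so the step can be read only as a lower bound on the true size of the change: the limit of > 1000000 nM in this assay, at which 1 of the 4 values shown sits.

The change is small in what can be counted, with cyclobutyl bringing one four-membered non-aromatic ring where isopropyl has no ring, and neither group carrying a hydrogen-bond donor, a hydrogen-bond acceptor or a net charge.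

The compounds shown do not separate the effect of the ring from that of the added carbon, and it remains open how cyclopropyl, cyclopentyl or tert-butyl on the same nitrogen would read. As far as these compounds go, it is also open whether cyclobutyl gives a step of similar size when the amide-type nitrogen carries hydrogen, as it does in compound 1.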